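Moving one amino group within a closely matched pair

The source may hold more compounds than are shown below. What is called first, only, known or untested is meant among the compounds shown, and "the series" means these compounds.

Within the data shown here, in a functional assay on HL-60 cells (Homo sapiens), with a stated time of 48 h (on this read-out lower numbers stand for an effect already at smaller amounts and higher numbers for an effect only at larger amounts of compound), two compounds have numbers so far. Compound 1 `CC1(C)CCC(C)(C)c2cc(/C=C/c3cccc(N)c3)ccc21` gives 40000 nM and compound 2 `CC1(C)CCC(C)(C)c2cc(/C=C\c3ccc(N)cc3)ccc21` gives 38000 nM in this test, numbers within the usual scatter of each other, so compound 2 stands level with compound 1. Compound 3 `CC1(C)CCC(C)(C)c2cc(/C=C\c3cccc(N)c3)ccc21`, not yet measured, differs from compound 2 in one place (3-aminophenyl in place of 4-aminophenyl on a double-bonded chain carbon bound to a double-bonded chain carbon): it has 3-aminophenyl in place of 4-aminophenyl on a double-bonded chain carbon bound to a double-bonded chain carbon. Among the measured compounds shown here, no measured pair shows this swap alone, so the guidance is thin. Compound 1 also carries 3-aminophenyl and gives 40000 nM without standing apart from compound 2, so no change beyond the scatter is expected in this assay for this swap. The estimated step is small (a 1.1-fold lower number from compound 2 to compound 3 (0.04 log units; within the scatter)). For compound 3 the expected value is 35000 nM with an estimated range from 15000 nM to 60000 nM as the likely span.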

Compound 3, concentration for half-maximal activity: 10000 nM
The estimate for compound 3 lay 3.5-fold (0.54 log units) above the measured number; measured number outside the range, below it.
By their numbers in this assay, from the lowest: compound 3; then compounds 2 and 1 (each within the scatter of the next).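

In this assay, the choice between 4-aminophenyl and 3-aminophenyl does matter once the double bond is drawn Z, with a 3.8-fold lower number from compound 2 to compound 3 (0.58 log units; beyond the scatter). With 3-aminophenyl held fixed, the drawing of the double bond matters too, with a 4.0-fold lower number from compound 1 to compound 3 (0.60 log units; beyond the scatter). Compound 3, which joins 3-aminophenyl to the Z double bond, therefore stands apart from both neighbours, and its gap to compound 1 can be traced to a single feature: the fact that compounds 1 and 3 differ only in the configuration as drawn.

As far as these compounds go, it remains open how 4-aminophenyl behaves on a double bond drawn E, so the two changes cannot yet be judged fully against each other. From the compounds shown here alone, it is also open whether a hydroxyl group or a carboxylic acid in place of the amine would show the same preference for the 3-position and the Z double bond.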